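Hydrazone aryl variation on the shared core: toward compound 4

This account rests on a few compounds, and the source may have more. Where it says the series, first, only, none or still open, it means among the compounds named here.

Measured so far:
compound 1, `CN(C)CCn1cnnc1-c1cc(Oc2ccc(NC(=O)N/N=C/c3cccc(Cl)c3Cl)cc2F)ccn1`: 13200 nM
compound 2, `CN(C)CCn1cnnc1-c1cc(Oc2ccc(NC(=O)N/N=C/c3ccc(O)c(Br)c3)cc2F)ccn1`: 12400 nM
compound 3, `Cn1ncnc1-c1cc(Oc2ccc(NC(=O)N/N=C/c3ccccc3)cc2F)ccn1`: > 100000 nM

In a functional assay on U-87MG ATCC cells (Homo sapiens) for cytotoxicity, read by MTT assay, with a stated time of 72 h (on this read-out higher numbers stand for weaker inhibition and lower numbers for stronger inhibition), compound 1 gives 13200 nM. Compound 2 gives 12400 nM in this assay. For compound 3 the value > 100000 nM in this assay is a limit, not a number; one of the three results sits at the limit of > 100000 nM in this assay, at which 1 of the 3 values shown sits. Among the two numbers, compound 2 holds the lower one, with compound 1 nearest, and the single step of a 1.1-fold lower number from compound 1 to compound 2 (0.03 log units; within the scatter) stays within the scatter, so the two cannot be ordered. For the measured compounds named here, compound 3 differs from compound 2 at more than one place, and no single step connects them.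

Compound 4, `COc1cc(/C=N/NC(=O)Nc2ccc(Oc3ccnc(-c4nncn4CCN(C)C)c3)c(F)c2)ccc1O`, differs from compound 2 by methoxy in place of bromo on an aromatic carbon. Going by the values given here, the only measured step bearing on this is a 1.1-fold lower number from compound 1 to compound 2 (0.03 log units; within the scatter), which also exchanged the aryl group on the carbon with a double bond to nitrogen and moved nothing beyond the scatter. The step of a 1.0-fold higher number from compound 2 to compound 4 (0.02 log units; within the scatter) is therefore expected to remain within the scatter. Compound 4 is estimated at 13000 nM, with a range of 5000 nM to 40000 nM.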

Compound 4, half-maximal inhibitory concentration: > 100000 nM
Compound 4 gave a limit, no number; the forecaster's own chance of this, stated with the estimate: 10%; middle value at least 7.6-fold (0.88 log units) away from the limit.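

In this assay compound 4 sits at a limit, > 100000 nM, and not at a number. Methoxy in place of bromo on the aromatic carbon ortho to a hydroxy group gives an at least 8.0-fold higher number from compound 2 to compound 4 (0.90 log units; beyond the scatter), so this position responds to the change, whereas the exchange of whole aryl groups in a 1.1-fold lower number from compound 1 to compound 2 (0.03 log units; within the scatter) stayed within the scatter; the comparison with the dichlorophenyl compound reads an at least 7.5-fold higher number from compound 1 to compound 4 (0.87 log units; beyond the scatter). Both new steps are lower bounds on size, and the read-out reaches the same limit more than once: the limit of > 100000 nM in this assay, at which 2 of the 4 values shown sit.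

Open, on these data alone, is whether the response is specific to methoxy or follows any replacement of bromo here; a methyl, an amine or a longer ethoxy chain at this carbon would separate the two. Also open is the part played by the hydroxy group, which no pair shown varies alone.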